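Amide nitrogen swap: compound 2 to compound 3

The compounds below may be only part of what the source reports. "The series", "measured", "known", "first", "only" and "open" are said of these compounds alone.

Measured compounds:
compound 1, `COc1cc2c(cc1OC)C(CC(=O)O)CC2`: in a functional assay on the whole organism (strain Wistar) for inhibition, with Rattus norvegicus as the target, read by paw edema, with a stated time of 24 h, at a dose of 100 mg/kg (a lower number here means less inhibition, a higher number more inhibition at the dose given (going by the name of the read-out)), compound 1 gives 26.7%
compound 2, `COc1cc2c(cc1OC)C(CC(=O)Nc1cccc(C)c1)CC2`: in this assay compound 2 gives 41.7%

Going by the values given here, compound 2 stands highest of the two numbers so far; its only neighbour is compound 1, and the step of a number 15 percentage points higher from compound 1 to compound 2 (beyond the scatter) lies beyond the scatter. Among the compounds with values here, that step changes the carbonyl substituent, hydroxy to (3-methylphenyl)amino, and is the sole measured step.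

Compound 3, `COc1cc2c(cc1OC)C(CC(=O)Nc1ccncc1)CC2`, is not yet measured. Its change from compound 2 is pyridin-4-yl in place of 3-methylphenyl on an amide-type nitrogen. Within the data shown here, no measured pair exchanges one aromatic ring for another on the amide nitrogen, so the step of a number 15 percentage points higher from compound 1 to compound 2 (beyond the scatter) bears on it only in showing that an arylamide on this core reads higher than the free acid; it gives no direction for the ring swap itself. With both compounds 2 and 3 carrying an amide, the expectation is a step of a number 3.7 percentage points lower from compound 2 to compound 3 (within the scatter) in this assay, that is, no change beyond the scatter, with the estimate centred near the value of compound 2. Compound 3 is therefore expected to give about 38% in this assay, within 22% to 54%.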

Compound 3, a percentage reported as inhibition, in the whole organism at one dose (the size of the read-out at that dose, not a potency): 46.7%
Estimate against measurement, compound 3: 8.7 percentage points below; measured number inside the range.
By their numbers in this assay, from the lowest: compound 1; then compounds 2 and 3 (each within the scatter of the next).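

In this assay, going by these compounds alone, the ring on the amide-type nitrogen can be exchanged without the reading leaving the scatter: a number 5 percentage points higher from compound 2 to compound 3 (within the scatter) is the first measured step at this place, and it does not separate pyridin-4-yl from 3-methylphenyl, although the two differ in ring composition and pyridin-4-yl carries a hydrogen-bond acceptor. The higher reading of the arylamides over the free acid is also no longer tied to 3-methylphenyl, since a number 20 percentage points higher from compound 1 to compound 3 (beyond the scatter) stands alongside a number 15 percentage points higher from compound 1 to compound 2 (beyond the scatter), and both steps lie beyond the scatter. No available evidence bears on why these two rings cannot be told apart in this test.

The compounds shown leave open whether a ring is needed on the amide-type nitrogen at all, as an unsubstituted amide or a saturated amine such as morpholine would test, and whether a benzyl group, with its longer link to the ring, would read differently. They also leave open how far the reading depends on the ring nitrogen's place, which pyridin-3-yl or pyridin-2-yl would address.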